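Swapping phenethyl for 4-fluorophenyl in compound 2

This account rests on a few compounds, and the source may have more. Where it says the series, first, only, none or still open, it means among the compounds named here.

Of the compounds shown here, three have been tested so far in a functional assay on PANC-1 cells (Homo sapiens) for cytotoxicity, read by WST assay, with a stated time of 24 h (a lower number here means a stronger inhibitor, a higher number a weaker inhibitor), and none has yielded a number. Compound 1 `S=C(CCCCCCCCc1ccccc1)N1CCCCC1` gives > 100000 nM as a limit of the assay. Compound 2 `O=C(CCCCCCCCCCc1ccccc1)N1CCCCC1` gives > 100000 nM as a limit too. Compound 3 `O=C(CCCOCCCCc1ccccc1)N1CCCCC1` likewise gives > 100000 nM as a limit. Compound 2 therefore has no exact value, and its place is the limit of > 100000 nM in this assay, at which 3 of the 3 values shown sit, as the data stand.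

Compound 4 `O=C(CCCCCCCCc1ccc(F)cc1)N1CCCCC1` differs from compound 2 as follows: 4-fluorophenyl in place of phenethyl on a saturated chain carbon, eight bonds along the chain from a carbonyl carbon.

Among the measured compounds shown here, no measured pair shows what a single change does in this assay so the limits are the only guide. With compound 2 at > 100000 nM as a limit, no clear gain is expected here. The estimated step of a number no higher from compound 2 to compound 4 (the limit leaves the size open) is none beyond the scatter, in either direction. The expected value for compound 4 is 100000 nM with an estimated range of 30000 nM to 300000 nM. Compound 4 may well yield only a limit too.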

Compound 4, half-maximal inhibitory concentration: 99800 nM
Beside the measured number, compound 4's estimate is 1.0-fold (0.00 log units) above it; low and high end bracket the measured number.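

Among the compounds shown here, compound 4 is the first compound in this assay to give a number rather than a limit: compound 4 gives 99800 nM. Compound 2 gives > 100000 nM, which is a limit of the assay and not a number. The change therefore reads as a number no higher from compound 2 to compound 4 (the limit leaves the size open), so its direction is known but its size cannot be read, and compound 2 remains at the limit: the limit of > 100000 nM in this assay, at which 3 of the 4 values shown sit.

A plain phenyl at this place, eight bonds along the chain from a carbonyl carbon, would separate the part played by the fluorine from that of the shorter group. Going by these compounds, whether a chlorine or a methoxy group on the ring, or an amine on the chain, would bring the value further down the scale also stays open.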